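Pyridin-2-yl for Acetyl on the Piperazine of Compound 1

The source may report more compounds than this note shows. Statements on the series, on what has been measured and on what is new or still open speak of the compounds shown alone.

Measured compounds:
compound 1 `CC(=O)N1CCN(c2ccc([C@H]3CN(Cc4c(C)cccc4F)C[C@@H]3N(C)C)cc2)CC1` — 2.6 nM
compound 2 `Cc1cccc(F)c1CN1C[C@H](C2CCN(c3cnc(C(N)=O)cn3)CC2)[C@@H](N(C)C)C1` — 0.65 nM
compound 3 `Cc1cccc(F)c1CN1C[C@H](c2ccc(-c3cnn(CC(N)=O)c3)cc2)[C@@H](N(C)C)C1` — 2.6 nM

All three were tested in an assay on isolated protein for binding affinity to Polycomb protein EED (Homo sapiens), read by TR-FRET and LanthaScreen, with a stated time of 1 h; on this read-out lower numbers stand for stronger inhibition and higher numbers for weaker inhibition. Compound 1 stands level with compound 3 at the digits given, and together they hold the highest numbers of the set; compound 2 lies below both, beyond the scatter. For the measured compounds named here, the one single-point step recorded is no change at the digits printed from compound 1 to compound 3 (within the scatter), a swap of the whole substituent on an aromatic carbon.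

Compound 4 `Cc1cccc(F)c1CN1C[C@H](c2ccc(N3CCN(c4ccccn4)CC3)cc2)[C@@H](N(C)C)C1` differs from compound 1 as follows: pyridin-2-yl in place of acetyl on an amine nitrogen in a ring

Going by the values given here, no measured step alters the group on the amine nitrogen in a ring, so the account rests on the tolerance seen in no change at the digits printed from compound 1 to compound 3 (within the scatter). Compound 4 is therefore expected to show a 1.0-fold lower number from compound 1 to compound 4 (0.02 log units; within the scatter), that is, no step beyond the scatter. Compound 4 is estimated at 2.5 nM, with a range from 0.8 nM to 8 nM.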

Compound 4, inhibition constant: 2.1 nM
The estimate for compound 4 lay 1.2-fold (0.08 log units) above the measured number; low and high end bracket the measured number.
By their numbers in this assay, from the lowest: compound 2; then compounds 4, 1 and 3 (each within the scatter of the next).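

For the compounds shown here, this is the first step at the amine nitrogen in a ring itself; the earlier step replaced the whole substituent on the aromatic carbon. In this assay, pyridin-2-yl in place of acetyl gives a 1.2-fold lower number from compound 1 to compound 4 (0.09 log units; within the scatter), so the carbonyl of acetyl is not needed on this nitrogen to keep the number in this range, and a six-membered aromatic ring is accepted there. Nothing available explains this tolerance. The compounds shown leave open whether a carboxylic acid, a primary amine or a longer chain on this nitrogen would keep the number in this range.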